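Chain Shortening and Methoxy for Bromine on the Benzyl Ring

A few compounds are considered here, and "the series" means these few. Any claim that something is new, unique, unknown or untested is made for them only; others in the source may bear on it.

In a functional assay on MCF7 cells (Homo sapiens) for inhibition, read by MTT assay, with a stated time of 72 h (a higher number here means a weaker inhibitor of growth, a lower number a stronger inhibitor of growth), compound 1 `O=S(=O)(NCCCCNCc1ccc(Br)cc1)c1cc(C(F)(F)F)cc(C(F)(F)F)c1` gives 1500 nM. Its companions are compound 2 `COc1ccc(CNCCCNS(=O)(=O)c2cc(C(F)(F)F)cc(C(F)(F)F)c2)cc1OC`, which gives 1900 nM, and compound 3 `O=S(=O)(NCCCNCc1ccc(C(F)(F)F)cc1)c1cc(C(F)(F)F)cc(C(F)(F)F)c1`, which gives 1400 nM; all three numbers sit within the usual scatter of one another, so compound 1 holds no distinct place among them. Among the compounds with values here, the single measured step, a 1.4-fold lower number from compound 2 to compound 3 (0.13 log units; within the scatter), swaps the ring on a saturated chain carbon bound to an amine nitrogen and moves nothing beyond scatter. Compound 4 `COc1ccc(CNCCCNS(=O)(=O)c2cc(C(F)(F)F)cc(C(F)(F)F)c2)cc1` differs from compound 1 by (4-methoxybenzyl)amino in place of ((4-bromobenzyl)amino)methyl on a saturated chain carbon, three bonds along the chain from a sulfonamide nitrogen. That step from compound 2 to compound 3 is the nearest guide, and it suggests no shift beyond scatter. The step that is expected on this basis is estimated as a 1.1-fold higher number from compound 1 to compound 4 (0.05 log units; within the scatter). Compound 4 is therefore estimated at 1700 nM in this assay, with a range from 800 nM to 3600 nM.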

Compound 4, concentration for 50% growth inhibition: 2500 nM
The estimate for compound 4 lay 1.5-fold (0.17 log units) below the measured number; low and high end bracket the measured number.
By their numbers in this assay, from the lowest: compounds 3, 1, 2 and 4 (each within the scatter of the next).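

In this assay the swap of ((4-bromobenzyl)amino)methyl for (4-methoxybenzyl)amino gives a 1.7-fold higher number from compound 1 to compound 4 (0.22 log units; within the scatter) and so changes the chain and the ring group together without moving the number beyond the scatter. On an aromatic carbon, methoxy in place of trifluoromethyl gives a 1.8-fold higher number from compound 3 to compound 4 (0.25 log units; within the scatter) and hydrogen in place of methoxy gives a 1.3-fold higher number from compound 2 to compound 4 (0.12 log units; within the scatter) with the same outcome. Compound 4 thus extends the flat picture to a further ring pattern at this position.

On these data alone, whether a carboxylic acid on the ring or a longer chain would shift the number remains open. No measurement at hand accounts for these numbers.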